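This account rests on a few compounds, and the source may have more. Where it says the series, first, only, none or still open, it means among the compounds named here.

Two members of this series have been examined in a functional assay on A549 cells (Homo sapiens) for cytotoxicity, read by MTT assay, with a stated time of 2 days; a lower number here means a stronger inhibitor, a higher number a weaker inhibitor. Compound 1, `O/N=C1/C(c2c[nH]c3ccc(OCc4ccccc4)cc23)=Nc2ccc(OCc3ccccc3)cc21`, carries a benzyloxy group on each of its two ring systems and a free oxime; in this assay compound 1 gives 19500 nM. Compound 2, `c1ccc(CO/N=C2/C(c3c[nH]c4ccccc34)=Nc3ccccc32)cc1`, drops both benzyloxy groups and instead carries the benzyl on the oxime oxygen; in this assay compound 2 gives 19300 nM. The two numbers lie within the scatter of each other, so neither compound can be told apart from the other on this read-out.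

Compound 3, `FC(F)(F)c1ccc(CO/N=C2/C(c3c[nH]c4ccccc34)=Nc3ccccc32)cc1`, is the next step from compound 2: trifluoromethyl in place of hydrogen on an aromatic carbon, with the phenyl of the benzyl becoming 4-(trifluoromethyl)phenyl. Going by the values given here, no pair among the measured compounds shows what such a change does here, so the step of a 1.3-fold lower number from compound 2 to compound 3 (0.11 log units; within the scatter) is expected to stay small and to fall within the scatter. Compound 3 is accordingly estimated at 15000 nM, with a range from 5000 nM to 45000 nM.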

Compound 3, half-maximal inhibitory concentration: 21900 nM
Beside the measured number, compound 3's estimate is 1.5-fold (0.16 log units) below it, within the range that was stated.
By their numbers in this assay, from the lowest: compounds 2, 1 and 3 (each within the scatter of the next).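

Going by these compounds alone, the replacement of hydrogen by trifluoromethyl on an aromatic carbon, para to a large group, gives the first single-place step: a 1.1-fold higher number from compound 2 to compound 3 (0.05 log units; within the scatter) in this assay. The change from phenyl to 4-(trifluoromethyl)phenyl adds 4 heavy atoms, yet it leaves the read-out of this assay unmoved beyond the scatter, so this place accepts trifluoromethyl without a measurable effect on the number. Nothing available on the compounds offers an explanation for this result.

On these data alone, whether an amine, a carboxylic acid or a methoxy group at the same place would shift the number remains open. Compound 1 and compound 2 differ in more than one place, so the separate contributions of the two benzyloxy groups and of the benzyl on the oxime oxygen also remain unresolved.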